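Configuration change at the ring carbon, compound 2 to compound 3

A few compounds are considered here, and "the series" means these few. Any claim that something is new, unique, unknown or untested is made for them only; others in the source may bear on it.

Two compounds carry numbers in an ADME assay on liver for metabolic stability, with Liver microsome (Homo sapiens) as the target, read by LC-MS, using microsomes, with a stated time of 5 h; a lower number here means slower removal, a higher number faster removal of the compound. Compound 1 `O[C@H](c1ccccn1)[C@]1(c2ccc(C(F)(F)F)cc2)C[C@@H](O)C1` gives 33.3 mL/min/kg in this assay. Compound 2 `O[C@H](c1ccccn1)[C@@]1(c2ccc(Cl)c(Cl)c2)CCO1` gives 217 mL/min/kg in this assay, the higher of the two numbers, and its gap to compound 1 lies beyond the scatter. Among the compounds with values here, no pair of measured compounds differs in one place, so no step between measured compounds can be read from these data. Compound 3 `O[C@H](c1ccccn1)[C@]1(c2ccc(Cl)c(Cl)c2)CCO1` is not yet measured in this assay. It differs from compound 2 thus: the two compounds have the same atoms and bonds and differ only in configuration as drawn: 1 of 2 stereo elements differ; a stereocentre at a saturated ring carbon is drawn S in compound 2 and R in compound 3. Within the data shown here, nothing among the measured compounds speaks to a change of configuration alone, so the expected step from compound 2 to compound 3 in this assay is none beyond the scatter, with its direction open. In this assay compound 3 is estimated at 180 mL/min/kg, with a range of 80 mL/min/kg to 400 mL/min/kg. The implied step, a 1.2-fold lower number from compound 2 to compound 3 (0.08 log units; within the scatter), is expected to stay within the scatter.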

Compound 3, clearance: 66.7 mL/min/kg
For compound 3 the middle estimate is 2.7-fold (0.43 log units) above the measured one; measured number below the stated range.
By their numbers in this assay, from the lowest: compounds 1 and 3 (each within the scatter of the next); then compound 2.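

In this assay, turning the stereocentre at a saturated ring carbon from S to R gives a 3.3-fold lower number from compound 2 to compound 3 (0.51 log units; beyond the scatter). Within the data shown here, this is the first pair that differs in one place, and it shows that this position is sensitive to configuration: with atoms and bonds unchanged, the arrangement as drawn moves the number beyond the scatter. The step can be assigned to this stereocentre alone because nothing else separates the pair: the fact that compounds 2 and 3 differ only in the configuration as drawn

A single pair cannot show whether the same direction and size of step hold on other members of the series, or what inverting the other stereocentre would do. Also open, from the compounds shown here alone, is how the R arrangement behaves once an amine or a carboxylic acid is carried on the shared core.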